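Nitro to bromo on the glycosyl triazole series

The source may report more compounds than this note shows. Statements on the series, on what has been measured and on what is new or still open speak of the compounds shown alone.

- compound 1 `CC(=O)OC[C@H]1O[C@H](OC[C@@H](Cn2cc(CN(c3nc(-c4ccc([N+](=O)[O-])cc4)no3)C3CCCCC3)nn2)OC(C)=O)C=C[C@@H]1OC(C)=O`: > 200 ug/mL (a limit)
- compound 2 `C#CCN(c1nc(-c2ccc(C)cc2)no1)C1CCCCC1`: 91.9 ug/mL

The read-out is an ADME assay on HepG2 cells (Homo sapiens) for cytotoxicity, read by MTT assay, with a stated time of 48 h; a higher number here means that more compound is tolerated, a lower number that less compound is tolerated. In this assay compound 1 gives > 200 ug/mL, which is a limit of the assay and not a number. The record for it reads (the limit of > 200 ug/mL in this assay, at which 1 of the 2 values shown sits). Among the measured compounds shown here, compound 2 gives 91.9 ug/mL in this assay, but no measured pair isolates the change considered here.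

Compound 3 `CC(=O)OC[C@H]1O[C@H](OC[C@@H](Cn2cc(CN(c3nc(-c4ccc(Br)cc4)no3)C3CCCCC3)nn2)OC(C)=O)C=C[C@@H]1OC(C)=O` carries one change from compound 1: bromo in place of nitro on an aromatic carbon. In words, bromo in place of nitro on an aromatic carbon, that is, 4-nitrophenyl to 4-bromophenyl.

No shift beyond the usual scatter is expected in this assay. The expected change is a step that the limit leaves unreadable from compound 1 to compound 3. For compound 3 the estimated value is 210 ug/mL, within an expected range of 110 ug/mL to 400 ug/mL. The assay may well report only a limit again.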

Compound 3, half-maximal cytotoxic concentration: 47.6 ug/mL
For compound 3 the middle estimate is 4.4-fold (0.64 log units) above the measured one, outside the stated range (below it).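

In this assay, among the compounds shown here, the change from 4-nitrophenyl to 4-bromophenyl gives an at least 4.2-fold lower number from compound 1 to compound 3 (0.62 log units; beyond the scatter) in the only single-place comparison so far, so this aromatic carbon is not a silent position for tolerance in HepG2 cells. Compound 1 gives > 200 ug/mL here, which is a limit of the assay and not a number. The step is a floor on the true size, not a fixed value: the limit of > 200 ug/mL in this assay, at which 1 of the 3 values shown sits.

For the compounds shown here, with only two groups compared at this carbon, it stays open whether the shift tracks the loss of nitro or the arrival of bromo, and whether a nitrile, a methoxy or a chloro group would sit with compound 1 or with compound 3. Compound 2 differs from compound 3 in more than one place and gives no reading on this change.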